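Swapping methoxy for cyclopropyl on the pyrimidine ring

A few compounds are considered here, and "the series" means these few. Any claim that something is new, unique, unknown or untested is made for them only; others in the source may bear on it.

Compound 1 `COc1ncc(-c2nc(C(F)(F)F)sc2N2CCN(C(=O)Cn3cnc4cccnc43)[C@H](C)C2)cn1`: 158 nM in an assay on blood for inhibition of C-X-C chemokine receptor type 3 (Homo sapiens), with a stated time of 30 min; on this read-out lower numbers stand for stronger inhibition and higher numbers for weaker inhibition
Compound 2 `COc1ncc(-c2nc(C(F)(F)F)sc2N2CCN(C(=O)Cn3nc(C)nc3C)[C@H](C)C2)cn1`: 1040 nM in this assay

Within the data shown here, compound 2 stands at the higher of the two numbers in this assay, which here means the weaker inhibitor of the pair; its only neighbour is compound 1. Among the measured compounds shown here, the single measured step, a 6.6-fold higher number from compound 1 to compound 2 (0.82 log units; beyond the scatter), concerns the group on the saturated chain carbon bound to the carbonyl carbon, at the opposite end of the shared core.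

Compound 3 `Cc1nc(C)n(CC(=O)N2CCN(c3sc(C(F)(F)F)nc3-c3cnc(C4CC4)nc3)C[C@H]2C)n1` is compound 2 with cyclopropyl in place of methoxy on an aromatic carbon, sitting between two ring nitrogen atoms and para to a large group. For the measured compounds named here, no measured step touches this part of the molecule, so there is nothing in the data to show a direction for this change. The measured step between compound 1 and compound 2 does not inform it. The expectation is therefore a step of no size beyond the scatter. Compound 3 is expected to give about 1000 nM in this assay, with a range from 300 nM to 3500 nM. That estimate amounts to a 1.0-fold lower number from compound 2 to compound 3 (0.02 log units; within the scatter), a change expected to stay within the scatter.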

Compound 3, half-maximal inhibitory concentration: 674 nM
For compound 3 the middle estimate is 1.5-fold (0.17 log units) above the measured one, and the stated range covers the measured number.
By their numbers in this assay, from the lowest: compound 1; then compounds 3 and 2 (each within the scatter of the next).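

The methoxy group and the cyclopropyl group can stand in for each other here: going from 2-methoxypyrimidin-5-yl to 2-cyclopropylpyrimidin-5-yl gives a 1.5-fold lower number from compound 2 to compound 3 (0.19 log units; within the scatter) in this assay, so compound 2 and compound 3 cannot be told apart on this read-out. Among these compounds, this is the first look at this end of the molecule, and it shows that, with the dimethyl-substituted five-membered ring kept at the other end, losing the oxygen and its single hydrogen-bond acceptor and bringing in a three-membered ring of carbon only leaves the number within the usual scatter. Nothing measured alongside these compounds offers an explanation for this result.

One pair cannot show whether the same swap would hold on compound 1, which carries a different group at the far end of the molecule. Also open, as far as these compounds go, is how this place on the pyrimidine ring would respond to something quite different from both groups, such as an amine like dimethylamino, a longer chain like propoxy, or a carboxylic acid.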